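A few compounds are considered here, and "the series" means these few. Any claim that something is new, unique, unknown or untested is made for them only; others in the source may bear on it.

Compound 1 `O=C(O)c1ccccc1-c1ccc(CCc2ncc(CC3CCOCC3)[nH]2)cc1` is the starting point. In an in vitro functional assay on cells for agonist activity at Bombesin receptor subtype-3 (Homo sapiens), read by luminescence and calcium flux (a lower number here means that less compound is needed, a higher number that more compound is needed for the effect), compound 1 gives 338 nM, the highest of the two numbers measured; compound 2 `O=C(O)c1ccccc1-c1ccc(CCc2ncc(Cc3cccc(F)c3)[nH]2)cc1` gives 159 nM in this assay. Compound 3 `O=C(O)c1ccccc1-c1ccc(CCc2ncc(Cc3cccc(F)c3F)[nH]2)cc1` differs from compound 1 as follows: 2,3-difluorophenyl in place of oxan-4-yl on a saturated chain carbon bound to an aromatic carbon. Among the compounds with values here, the only measured step that bears on this change is a 2.1-fold lower number from compound 1 to compound 2 (0.33 log units; beyond the scatter), where the same saturated ring left and a fluorine-bearing aromatic ring entered. A similar direction is expected for compound 3, so its step is estimated as a 2.3-fold lower number from compound 1 to compound 3 (0.35 log units; beyond the scatter). Compound 3 is therefore expected to give about 150 nM in this assay, within a range of 60 nM to 400 nM.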

Compound 3, half-maximal effective concentration: 87 nM
The estimate for compound 3 lay 1.7-fold (0.24 log units) above the measured number; low and high end bracket the measured number.
By their numbers in this assay, from the lowest: compounds 3 and 2 (each within the scatter of the next); then compound 1.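

The step of a 3.9-fold lower number from compound 1 to compound 3 (0.59 log units; beyond the scatter) in this assay shows that a second fluorine-bearing aromatic ring can also take the place of oxan-4-yl on this saturated chain carbon, with the number again beyond the scatter from compound 1. The further fluorine gives a 1.8-fold lower number from compound 2 to compound 3 (0.26 log units; within the scatter), so compound 2 and compound 3 cannot be told apart here. Nothing available explains these numbers. Still open, from the compounds shown here alone, is how a pyridine ring, or an amine on the aromatic ring, would fare at this place. Going by these compounds, a longer chain carrying the 2,3-difluorophenyl is equally open.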